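The source may hold more compounds than are shown below. What is called first, only, known or untested is meant among the compounds shown, and "the series" means these compounds.

Measured so far:
compound 1, `O=[N+]([O-])c1ccc2[nH]c(CSCc3nc4cc([N+](=O)[O-])ccc4[nH]3)nc2c1`; in an ADME assay on WI-38 cells (Homo sapiens) for cytotoxicity, read by MTT assay, with a stated time of 48 h (on this read-out lower numbers stand for stronger inhibition and higher numbers for weaker inhibition), compound 1 gives 25400 nM
compound 2, `O=C(CSCc1nc2cc([N+](=O)[O-])ccc2[nH]1)c1ccc(Cl)cc1`; in this assay compound 2 gives 33800 nM

Compound 2 and compound 1 sit within the scatter of each other in this assay, so no order between them can be read. Compound 3, `O=C(CSCc1nc2cc([N+](=O)[O-])ccc2[nH]1)c1ccc(Br)cc1`, carries bromo in place of chloro on an aromatic carbon. For the measured compounds named here, no step between measured compounds covers this exchange. For this assay the step from compound 2 to compound 3 is expected to stay inside the scatter, with no direction claimed: a 1.1-fold lower number from compound 2 to compound 3 (0.05 log units; within the scatter). Compound 3 is therefore estimated at 30000 nM, with a range from 15000 nM to 60000 nM.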

Compound 3, half-maximal inhibitory concentration: 31500 nM
The estimate for compound 3 lay 1.1-fold (0.02 log units) below the measured number, within the range that was stated.
By their numbers in this assay, from the lowest: compounds 1, 3 and 2 (each within the scatter of the next).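

With the 4-chlorophenyl changed to 4-bromophenyl, a 1.1-fold lower number from compound 2 to compound 3 (0.03 log units; within the scatter) in this assay, so this exchange on the aromatic carbon gives no readable change. For the compounds shown here, this is the first comparison that differs in one place, and no order can be read between the two halogens. Nothing available bears on a reason for this result. As far as these compounds go, whether an amine or a carboxylic acid on the same aromatic carbon would give a step beyond the scatter remains open. From the compounds shown here alone, a longer chain in the linker remains open as well.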